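Swapping the aryl group on the shared core

The source may hold more compounds than are shown below. What is called first, only, known or untested is meant among the compounds shown, and "the series" means these compounds.

Compound 1 (`COc1cccc(CNCCCNc2ccnc3cc(Oc4ccccc4)ccc23)c1O`) gives 14500 nM
Compound 2 (`COc1ccc(Oc2ccc3c(NCCCNCc4cc(F)ccc4OC)ccnc3c2)cc1`) gives 14500 nM

In a physicochemical assay for solubility, with a stated time of 18 h, at pH 7.4 (a lower number here means a less soluble compound, a higher number a more soluble compound), compound 1 and compound 2 stand level, with their values within the scatter of each other. Compound 3 (`COc1ccc(F)cc1CNCCCNc1ccnc2cc(Cc3ccc(F)cc3Cl)ccc12`) is still unmeasured. It departs from compound 2 as follows: 2-chloro-4-fluorobenzyl in place of 4-methoxyphenoxy on an aromatic carbon. In words, 2-chloro-4-fluorobenzyl stands in place of 4-methoxyphenoxy on an aromatic carbon of a six-membered aromatic ring of carbon only, part of a fused or bridged system of two rings. Going by the values given here, no measured pair isolates this swap, so the expectation is loose. The anchor is compound 2 at 14500 nM and a small fall in this assay is expected, not clearly beyond the scatter. The estimated change is a 1.8-fold lower number from compound 2 to compound 3 (0.26 log units; within the scatter) in this reading. The estimate for compound 3 is 8000 nM (2500 nM to 18000 nM).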

Compound 3, solubility: 4200 nM
Estimate against measurement, compound 3: 1.9-fold (0.28 log units) above, and the stated range covers the measured number.
By their numbers in this assay, from the lowest: compound 3; then compounds 1 and 2 (each within the scatter of the next).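

In this assay, going by these compounds alone, this position on the shared core gives the first readable single change, with a 3.5-fold lower number from compound 2 to compound 3 (0.54 log units; beyond the scatter) when 2-chloro-4-fluorobenzyl stands in place of 4-methoxyphenoxy. Compound 1 and compound 2 differ in more than one place, so their level values say nothing about this position alone. The two groups match in heavy atoms and in their six-membered aromatic ring of carbon only, yet the step is beyond the scatter, and no measurement at hand accounts for it.

The compounds shown do not separate the oxygen-to-carbon change at the attachment from the change of ring substituents, as a 2-chloro-4-fluorophenoxy group would. As far as these compounds go, how an amine such as morpholine or a carboxylic acid would read at this position also remains open.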